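A few compounds are considered here, and "the series" means these few. Any claim that something is new, unique, unknown or untested is made for them only; others in the source may bear on it.

Compounds measured so far:
compound 1 `CC(C)N1CCN(c2ccc3nnnc(Nc4cccc(OC(F)(F)F)c4)c3n2)CC1`, 13800 nM
compound 2 `CC(C)(C)OC(=O)N1CCC(CNc2ccc3nnnc(Nc4cccc(OC(F)(F)F)c4)c3n2)CC1`, > 100000 nM
compound 3 `FC(F)(F)Oc1cccc(Nc2nnnc3ccc(N4CCCC4)nc23)c1`, > 100000 nM

Of the compounds shown here, three sharing one core have been tested in a functional assay on PC-3 cells (Homo sapiens) for antiproliferative activity, read by MTT assay, with a stated time of 96 h; on this read-out lower numbers stand for stronger inhibition and higher numbers for weaker inhibition. Going by the values given here, compound 1 gives 13800 nM, the only reading that is a number. Compound 2 reports only a limit of the assay, > 100000 nM. Compound 3 likewise reports a limit, > 100000 nM. Compound 1 therefore stands alone with a numerical value, while the other two sit at the limit of > 100000 nM in this assay, at which 2 of the 3 values shown sit.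

Compound 4 `FC(F)(F)Oc1cccc(Nc2nnnc3ccc(Cl)nc23)c1` has not yet been measured; it differs from compound 1 by chloro in place of 4-isopropylpiperazin-1-yl on an aromatic carbon. Among the compounds with values here, the one measured step that bears on this change is an at least 7.2-fold higher number from compound 1 to compound 3 (0.86 log units; beyond the scatter), where exchanging the same group for pyrrolidin-1-yl already gave a limit rather than a number. Chloro brings no ring and no hydrogen-bond acceptor in its place. A step beyond the scatter toward weaker inhibition is therefore expected, of about a 5.8-fold higher number from compound 1 to compound 4 (0.76 log units; beyond the scatter). For compound 4 the estimate in this assay is 80000 nM, with a range from 20000 nM to 300000 nM, and a considerable chance that only a limit is reported.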

Compound 4, half-maximal inhibitory concentration: 5990 nM
Beside the measured number, compound 4's estimate is 13-fold (1.13 log units) above it; the whole stated range lies above it.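

In this assay, chloro in place of 4-isopropylpiperazin-1-yl gives a 2.3-fold lower number from compound 1 to compound 4 (0.36 log units; beyond the scatter), so at this aromatic carbon next to the ring nitrogen, a numerical reading does not depend on a non-aromatic ring or on hydrogen-bond acceptors in the substituent. Chloro in place of pyrrolidin-1-yl gives an at least 16-fold lower number from compound 3 to compound 4 (1.22 log units; beyond the scatter), which shows that losing 4-isopropylpiperazin-1-yl does not by itself weaken inhibition: compound 3 moves to a higher number and compound 4 to a lower one. Compound 3 reports a limit of the assay and not a number, so this second step is not an exact size: the limit of > 100000 nM in this assay, at which 2 of the 4 values shown sit.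

The compounds shown do not explain why chloro and pyrrolidin-1-yl lie so far apart at this position. Going by these compounds, whether a fluoro, a methoxy or a dimethylamino group here would read like chloro or like pyrrolidin-1-yl remains open, as does whether a piperazine without the isopropyl group would stay near compound 1.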